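Methyl added on the aryl urea of compound 2

The compounds below may be only part of what the source reports. "The series", "measured", "known", "first", "only" and "open" are said of these compounds alone.

Compound 2 `O=C(Nc1ccc(Cl)cc1)Nc1nc(Sc2c[nH]c3ccccc23)cc(N2CCCC2)n1` — 10400 nM
Compound 1 `COc1ccc(NC(=O)Nc2nc(Sc3c[nH]c4ccccc34)cc(N3CCCCC3)n2)cc1` — 17400 nM
Compound 3 `O=C(Nc1ccc(Cl)cc1)Nc1nc(Sc2c[nH]c3ccccc23)cc(N2CCCCC2)n1` — 42500 nM

In a functional assay on PC-3 cells (Homo sapiens) for inhibition, with a stated time of 72 h (a lower number here means a stronger inhibitor, a higher number a weaker inhibitor), compound 2 gives the lowest number of the three, although compound 1 sits within the scatter of it, so the two cannot be ranked; compound 3 lies clearly higher. Compound 4 `Cc1cc(Cl)ccc1NC(=O)Nc1nc(Sc2c[nH]c3ccccc23)cc(N2CCCC2)n1` differs from compound 2 by one change: methyl in place of hydrogen on an aromatic carbon.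

Among the measured compounds shown here, no measured step concerns this change directly. The step of a 2.4-fold higher number from compound 1 to compound 3 (0.39 log units; beyond the scatter) alters the group on the same aryl urea ring, and the step of a 4.1-fold higher number from compound 2 to compound 3 (0.61 log units; beyond the scatter) alters the other end of the shared core; both are modest, and neither adds a methyl on an aromatic carbon. The measured steps thus only show that changes to this aryl ring move this assay by modest amounts. Compound 4 is therefore expected to stay close to compound 2, with no step beyond the scatter, and its estimated step is a 1.2-fold lower number from compound 2 to compound 4 (0.06 log units; within the scatter). The estimate for compound 4 in this assay is 9000 nM, within a range from 3000 nM to 27000 nM.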

Compound 4, half-maximal inhibitory concentration: 12900 nM
Compound 4: the middle estimate sits 1.4-fold (0.16 log units) below what was measured, and the stated range covers the measured number.
By their numbers in this assay, from the lowest: compounds 2, 4 and 1 (each within the scatter of the next); then compound 3.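

In this assay, methyl in place of hydrogen on the aromatic carbon ortho to a large group and meta to a chloro group gives a 1.2-fold higher number from compound 2 to compound 4 (0.09 log units; within the scatter), so compound 2 and compound 4 cannot be ranked. Among the compounds shown here, this is the only direct reading of a substituent at this ring carbon, and it sets the change apart from the two earlier steps, a 2.4-fold higher number from compound 1 to compound 3 (0.39 log units; beyond the scatter) and a 4.1-fold higher number from compound 2 to compound 3 (0.61 log units; beyond the scatter), each of which lies beyond the scatter, whereas turning the 4-chlorophenyl into 4-chloro-2-methylphenyl does not. Nothing in the information available explains why this methyl leaves the number within the scatter.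

The compounds shown leave open whether a group other than methyl at this ring carbon, such as a methoxy group, an amine or a carboxylic acid, would also stay within the scatter of compound 2. They also leave open whether the 4-chloro-2-methylphenyl urea would behave in the same way with piperidin-1-yl, the group carried by compound 3, in place of pyrrolidin-1-yl.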